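One Aryl Swap Measured Against U-87 MG Cells

This account rests on a few compounds, and the source may have more. Where it says the series, first, only, none or still open, it means among the compounds named here.

Compound 1 `COc1ccccc1-c1csc(N/N=C/c2ccc(F)c(F)c2)n1` and compound 2 `Fc1ccc(/C=N/Nc2nc(-c3cccc(Br)c3)cs2)cc1F` share one core and differ in a single place: 3-bromophenyl in place of 2-methoxyphenyl on an aromatic carbon. In a functional assay on U-87MG ATCC cells for inhibition, with U-87 MG (Homo sapiens) as the target, read by MTT assay, with a stated time of 48 h (a higher number here means a weaker inhibitor, a lower number a stronger inhibitor), compound 1 gives 40600 nM. In this assay compound 2 gives 39900 nM. The step between them is a 1.0-fold lower number from compound 1 to compound 2 (0.01 log units; within the scatter), so the two compounds cannot be told apart by this measurement.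

Compound 3 `COc1ccccc1-c1csc(N/N=C/c2cc(OC)c(OC)c(Br)c2Br)n1` carries the same 2-methoxyphenyl group as compound 1 on a different core; the difference between the two cores is not broken down here. In this assay compound 3 reaches only a limit of the assay, > 100000 nM, which is the limit of > 100000 nM in this assay, at which 1 of the 3 values shown sits.

Compound 4 `COc1cc(/C=N/Nc2nc(-c3cccc(Br)c3)cs2)c(Br)c(Br)c1OC` has not yet been measured. It stands to compound 3 exactly as compound 2 stands to compound 1: 3-bromophenyl in place of 2-methoxyphenyl on an aromatic carbon. The place is described in the same words in both cases, so this is the same change made a second time.

Because a 1.0-fold lower number from compound 1 to compound 2 (0.01 log units; within the scatter) left the number where it was, the corresponding step is expected to be a step that the limit leaves unreadable from compound 3 to compound 4, of a similarly small size. Compound 4 is therefore estimated to give about 120000 nM in this assay, with a range from 40000 nM to 400000 nM, and it is likely that only a limit is reported. This expectation rests on the measured pair compound 1 and compound 2. Compound 3 itself contributes only a limit.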

Compound 4, half-maximal inhibitory concentration: 27600 nM
Compound 4: middle estimate off by 4.3-fold (0.64 log units), on the high side; measured number below the stated range.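

Carried onto the core of compound 3, the change of 2-methoxyphenyl to 3-bromophenyl gave an at least 3.6-fold lower number from compound 3 to compound 4 (0.55 log units; beyond the scatter) in this assay, whereas on the core of compound 1 it left the two compounds indistinguishable. The same change therefore did not carry over from one core to the other at the same size, and its effect in this small set depends on the core that bears it: the same change on two cores in this assay, a 1.0-fold lower number (0.01 log units; within the scatter) from compound 1 to compound 2 and an at least 3.6-fold lower number (0.55 log units; beyond the scatter) from compound 3 to compound 4, at least 3.5-fold (0.55 log units) apart, beyond the scatter of two such steps. What this does not show is the full size of the second step or why the two cores differ, and with only one pair on each core it gives no rule for any further core; the second step starts from a limit rather than a number: the limit of > 100000 nM in this assay, at which 1 of the 4 values shown sits.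

The compounds shown leave open which part of the difference between the two cores goes with the larger step, as that difference is not broken down into single changes. They also leave open whether the gap between the cores would appear with other groups at this place on the five-membered ring, such as a phenyl ring bearing an amine or a carboxylic acid in place of the bromine of 3-bromophenyl.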